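A few compounds are considered here, and "the series" means these few. Any claim that something is new, unique, unknown or untested is made for them only; others in the source may bear on it.

Compound 1 `CCCCCCCCc1ccc(OCC(=O)Cn2nnc(-c3ccccc3)n2)cc1` gives 8 in a physicochemical assay for lipophilicity, read by HPLC, tested at 5 mM; a higher number here means a more lipophilic compound, a lower number a more polar compound. Compound 2 `CCCCCCCCc1ccc(OCC(=O)Cn2nnc(C(=O)O)n2)cc1` gives 5.3. Compound 3 `CCCCCCCCc1ccc(OC(C)C(=O)Cn2nnc(-c3ccccc3)n2)cc1` gives > 8.

For compound 3 the value is a limit, not a number, so the compound sits at the limit of > 8 in this assay, at which 1 of the 3 values shown sits, and its exact place is open. Compound 4 `CC(Oc1ccc(Oc2ccc(F)cc2)cc1)C(=O)Cn1nnc(-c2ccccc2)n1` differs from compound 3 by 4-fluorophenoxy in place of octyl on an aromatic carbon. Two measured steps exist: a number 2.70 log units lower from compound 1 to compound 2 (beyond the scatter), and a number no lower from compound 1 to compound 3 (the limit leaves the size open). Neither swaps the octyl, so neither fixes the size of this change; only a rough expectation follows. In this assay a downward step is expected. The estimated step is a number at least 1.50 log units lower from compound 3 to compound 4 (beyond the scatter). Compound 4 is thus estimated at 6.5, with a range from 5.4 to 7.8.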

Compound 4, partition coefficient: 5.3
The estimate for compound 4 lay 1.20 log units above the measured number, outside the stated range (below it).
By their numbers in this assay, from the lowest: compounds 2 and 4 (each within the scatter of the next); then compound 1.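

Octyl and 4-fluorophenoxy carry the same number of heavy atoms, yet swapping one for the other on the aromatic carbon gives in this assay a number at least 2.70 log units lower from compound 3 to compound 4 (beyond the scatter). Among the compounds shown here, this is the first view of a change at this position, since the earlier steps all kept the octyl. Compound 3 holds a limit and not a number, so the size of this step is only a minimum: the limit of > 8 in this assay, at which 1 of the 4 values shown sits.

As far as these compounds go, whether a butyl chain or a plain phenoxy group at this position would give a smaller step stays open. So does whether a carboxylic acid on the compound 4 framework would give a further step.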